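Thioether variation on a shared selenium-containing core

This account rests on a few compounds, and the source may have more. Where it says the series, first, only, none or still open, it means among the compounds named here.

Measured compounds:
- compound 1 `Cc1ccccc1CSc1n[nH]c(-n2[se]c3ccccc3c2=O)n1` — 9720 nM
- compound 2 `O=c1c2ccccc2[se]n1-c1nc(SCc2ccc([N+](=O)[O-])cc2)n[nH]1` — 9140 nM

Both values come from a functional assay on A549 cells (Homo sapiens) for antiproliferative activity, read by CCK-8 assay, with a stated time of 48 h; on this read-out lower numbers stand for stronger inhibition and higher numbers for weaker inhibition. Compound 1 gives 9720 nM and holds the higher of the two numbers, but compound 2 at 9140 nM lies within the usual scatter of it, so the pair reads as two near-equal weak inhibitors of cell growth. No change at a single site has been measured in this series, so nothing is yet known about how the group on the sulfur shifts the read-out.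

Compound 3 `CC(C)Sc1n[nH]c(-n2[se]c3ccccc3c2=O)n1` differs from compound 1 in one place: isopropyl in place of 2-methylbenzyl on a sulfur. Going by the values given here, with no measured step to lean on, the expectation is a step from compound 1 to compound 3 of a 1.2-fold higher number from compound 1 to compound 3 (0.09 log units; within the scatter), most likely no change beyond the scatter and, if anything, toward a weaker read-out. Compound 3 is therefore expected to give 12000 nM in this assay, with a plausible range of 4000 nM to 35000 nM.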

Compound 3, half-maximal inhibitory concentration: 36600 nM
The estimate for compound 3 lay 3.1-fold (0.48 log units) below the measured number, and the stated range ends below it.
By their numbers in this assay, from the lowest: compounds 2 and 1 (each within the scatter of the next); then compound 3.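

Going by these compounds alone, the group on the sulfur does bear on the read-out: in this assay, isopropyl in place of 2-methylbenzyl gives a 3.8-fold higher number from compound 1 to compound 3 (0.58 log units; beyond the scatter) as the first measured step at this position, modest but beyond the scatter. The direction of this single step is toward weaker inhibition of cell growth when the group on the sulfur goes from 8 heavy atoms with a six-membered aromatic ring to 3 heavy atoms with no ring. No measurement at hand identifies which part of this change accounts for the step.

As far as these compounds go, whether the loss of the ring or the smaller size of the group matters more remains open, and an unsubstituted benzyl or an n-butyl chain on the same sulfur would help separate the two. Also open, from the compounds shown here alone, is how an amine or a carboxylic acid carried on a longer chain would read out here.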